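A Single Added Methyl on a Fast-Crossing Compound

A few compounds are considered here, and "the series" means these few. Any claim that something is new, unique, unknown or untested is made for them only; others in the source may bear on it.

For the measured compounds named here, in a physicochemical assay for permeability, using PAMPA (a lower number here means that the compound crosses the layer more slowly, a higher number that the compound crosses the layer faster), compound 2 (`Cc1ccc(-c2nc(CN3CCC(C(=O)NCCCN4C[C@H](C)C[C@H](C)C4)CC3)c(C)o2)cc1`) gives 274 10^-6 cm/s and is the only compound here with a true number. Compound 1 (`Cc1oc(-c2c(Br)cccc2Br)nc1CN1CCC(C(=O)NCCCN2C[C@H](C)C[C@H](C)C2)CC1`) gives < 1 10^-6 cm/s and that is a limit of the assay, not a number. Compound 3 (`Cc1ccc(-c2nc(CN3CCC(C(=O)NCCCN4C[C@H](C)C[C@H](C)C4)CC3)c(C)o2)c(C)c1`) carries methyl in place of hydrogen on an aromatic carbon, ortho to a large group (methyl in place of hydrogen on an aromatic carbon). Going by the values given here, the one measured step bearing on this, 4-methylphenyl in place of 2,6-dibromophenyl, is large (an at least 270-fold higher number from compound 1 to compound 2 (2.43 log units; beyond the scatter)) and beyond the scatter. This new change is much smaller, so only a modest fall is expected in this assay (a 1.6-fold lower number from compound 2 to compound 3 (0.21 log units; within the scatter)). Compound 3 is estimated at 170 10^-6 cm/s (expected range 40 10^-6 cm/s to 450 10^-6 cm/s).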

Compound 3, apparent permeability: 353 10^-6 cm/s
Beside the measured number, compound 3's estimate is 2.1-fold (0.32 log units) below it; measured number inside the range.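

In this assay, the added methyl gives a 1.3-fold higher number from compound 2 to compound 3 (0.11 log units; within the scatter), so compound 2 and compound 3 cannot be told apart and this position, ortho to a large group, accepts a methyl without a change beyond the scatter. The large gap remains with 2,4-dimethylphenyl in place of 2,6-dibromophenyl, an at least 350-fold higher number from compound 1 to compound 3 (2.54 log units; beyond the scatter), so one group at this position does not by itself bring compound 1's low reading. Compound 1 has a limit of the assay, not a number: the limit of < 1 10^-6 cm/s in this assay, at which 1 of the 3 values shown sits.

As far as these compounds go, whether the low reading follows from having two groups or from bromine itself stays open. A 2,6-dimethylphenyl or a 2-bromo-4-methylphenyl group would separate those two readings.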